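Cytotoxicity screen: biaryl cap swap from compound 2 to compound 3

The source may report more compounds than this note shows. Statements on the series, on what has been measured and on what is new or still open speak of the compounds shown alone.

Measured so far:
Compound 1 `COc1cc(F)cc(-c2ccc(C(=O)N(Cc3cccc(OCCCCCC(=O)O)c3)C(C)C)cc2)c1`: in an ADME assay on HEK293 cells (Homo sapiens) for cytotoxicity, read by CellTiter-Glo and resazurin assay, with a stated time of 72 h (on this read-out higher numbers stand for an effect only at larger amounts of compound and lower numbers for an effect already at smaller amounts), compound 1 gives only the limit > 26000 nM.
Compound 2 `CCOC(=O)CCCCCOc1cccc(CN(C(=O)c2ccc(-c3ccc4ccccc4c3)cc2)C(C)C)c1`: in this assay compound 2 gives only the limit > 26000 nM.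

Compound 2 therefore stands at a limit of this assay and not at a number. Among the compounds with values here, both values shown so far sit at the limit of > 26000 nM in this assay, at which 2 of the 2 values shown sit, so no measured step between two compounds exists, and no order among them can be read.

Compound 3 `CCOC(=O)CCCCCOc1cccc(CN(C(=O)c2ccc(-c3cccc(OCC)c3)cc2)C(C)C)c1` is the next compound, not yet measured in this assay. It differs from compound 2 in one place: 3-ethoxyphenyl in place of naphthalen-2-yl on an aromatic carbon.

Compound 1, which also carries a single six-membered aromatic ring bearing a small ether on the corresponding position, stays at its limit in this assay. On that basis the step from compound 2 to compound 3 is expected to be a number no higher from compound 2 to compound 3 (the limit leaves the size open), that is, no step beyond the scatter. Compound 3 is estimated at 26000 nM, with a range from 13000 nM to 52000 nM, and it is most likely to be reported again as a limit rather than a number.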

Compound 3, half-maximal effective concentration: > 22300 nM
Compound 3 was reported as a limit; the forecaster's own chance of this, stated with the estimate: 85%; the middle value lies beyond the limit too.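

In this assay compound 3 gives only the limit > 22300 nM. Within the data shown here, compound 2 also gives only a limit, > 26000 nM, and no step between compound 2 and compound 3 can be read from these two limits. The compounds shown leave open whether 3-ethoxyphenyl and naphthalen-2-yl differ at all on this read-out.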